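This account rests on a few compounds, and the source may have more. Where it says the series, first, only, none or still open, it means among the compounds named here.

Measured compounds:
- Compound 1, `NC1=C(C(=O)c2ccccc2)C(c2ccc(Br)cc2)N(CCCn2ccnc2)C1=O`: in a functional assay on A549 cells (Homo sapiens) for antiproliferative activity, read by MTT assay, with a stated time of 72 h (a higher number here means a weaker inhibitor, a lower number a stronger inhibitor), compound 1 is recorded as "not active" (no number reported), without a number.
- Compound 2, `O=C(C1=C(Nc2ccc(Br)cc2)C(=O)N(CCCn2ccnc2)C1c1ccc(Br)cc1)c1ccccc1`: in this assay compound 2 gives 22200 nM.

Among the measured compounds shown here, compound 2 holds the only numerical value in this assay; compound 1 carries no number that could be set against it, so no step between the two can be stated. Compound 2 is a weak inhibitor on this reading.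

Compound 3, `O=C(C1=C(Nc2cccc(Br)c2)C(=O)N(CCCn2ccnc2)C1c1ccc(Br)cc1)c1ccccc1`, differs from compound 2 in one place: 3-bromophenyl in place of 4-bromophenyl on an amine nitrogen. The change moves the bromine within the aryl group on the amine nitrogen and alters nothing else. For the measured compounds named here, no comparable step is available, so the expected effect rests on the size of the change alone. The step from compound 2 is expected to stay within the usual scatter, with no firm direction, a 1.1-fold lower number from compound 2 to compound 3 (0.05 log units; within the scatter). Compound 3 is expected to give about 20000 nM in this assay, within a range from 7000 nM to 60000 nM.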

Compound 3, half-maximal inhibitory concentration: 15800 nM
Compound 3: the middle estimate sits 1.3-fold (0.10 log units) above what was measured, within the range that was stated.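

In this assay, putting 3-bromophenyl in place of 4-bromophenyl on the amine nitrogen gives a 1.4-fold lower number from compound 2 to compound 3 (0.15 log units; within the scatter). Among the compounds shown here, this is the first step that can be read, and it shows that, for this pair, moving the bromine within the aryl group on the amine nitrogen does not separate the two compounds beyond the usual scatter. Nothing measured here bears on why the two values stand as they do.

Steps from compound 1 cannot be read, as it has no number, so the size of the effect of the aryl group on the amine nitrogen remains undefined. Also open, as far as these compounds go, is whether chlorine or methoxy in place of the bromine, or a benzyl group on that nitrogen, would move the value beyond the scatter.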